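A few compounds are considered here, and "the series" means these few. Any claim that something is new, unique, unknown or untested is made for them only; others in the source may bear on it.

Measured so far:
compound 1 `CC1CCN(c2nc(C(F)(F)F)ccc2CNC(=O)Nc2cccc3ccc(=O)[nH]c23)CC1` gives 492 nM in an assay on CHO cells for displacement of a labelled ligand from transient receptor potential cation channel subfamily V member 1 (Homo sapiens); a lower number here means a stronger inhibitor, a higher number a weaker inhibitor;
compound 2 `CC1CCN(c2nc(C(F)(F)F)ccc2CNC(=O)Nc2cccc3cc[nH]c(=O)c23)CC1` gives 239 nM in this assay.

Among the measured compounds shown here, compound 2 stands lowest of the two numbers, and the one step between them, a 2.1-fold lower number from compound 1 to compound 2 (0.31 log units; beyond the scatter), was modest. Compound 3 `CC1CCN(c2nc(C(F)(F)F)ccc2CNC(=O)Nc2ccc3[nH]c(=O)ccc3c2)CC1` is another rearrangement of the same atoms on the same amide-type nitrogen: a group of 11 heavy atoms (9 carbon, 1 nitrogen, 1 oxygen; one six-membered aromatic ring of carbon only, one six-membered aromatic ring with 1 hetero atom) in place of a group of 11 heavy atoms (9 carbon, 1 nitrogen, 1 oxygen; one six-membered aromatic ring of carbon only, one six-membered aromatic ring with 1 hetero atom), on an amide-type nitrogen. For the measured compounds named here, only that single step bears on it, and it shows how much such a shuffle of the bicyclic group can shift the number. For compound 3 the expected step is a 1.9-fold higher number from compound 2 to compound 3 (0.27 log units; within the scatter), with no direction clearly favoured. Compound 3 is therefore estimated at 450 nM, ranging from 120 nM to 1700 nM.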

Compound 3, inhibition constant: 39.9 nM
Beside the measured number, compound 3's estimate is 11-fold (1.05 log units) above it; measured number outside the range, below it.
By their numbers in this assay, from the lowest: compound 3; then compound 2; then compound 1.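

With a 6.0-fold lower number from compound 2 to compound 3 (0.78 log units; beyond the scatter) and a 12-fold lower number from compound 1 to compound 3 (1.09 log units; beyond the scatter) in this assay the picture changes, since the first pair showed only a modest shift. On this amide-type nitrogen, how the same atoms are joined within the bicyclic group can move the number substantially, and compound 3 is the strongest inhibitor of the three. Nothing available explains this gain. Still open, on these data alone, is whether other arrangements of these atoms would do better, and how the number would respond to an added amine or carboxylic acid on the bicyclic group.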